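This account rests on a few compounds, and the source may have more. Where it says the series, first, only, none or still open, it means among the compounds named here.

Compound 3 `CN1CCC(CNc2ccc(S(=O)(=O)NC(=O)c3ccc(N4CCN(CC5=C(c6ccc(C(F)(F)F)cc6)CC(C)(C)CC5)CC4)cc3Oc3cnc4[nH]ccc4c3)cc2[N+](=O)[O-])C1` stands at the high end of the three numbers in hand: in an assay on isolated protein for displacement of a labelled ligand from Apoptosis regulator Bcl-2 (Homo sapiens), with a stated time of 15 min (on this read-out higher numbers stand for weaker inhibition and lower numbers for stronger inhibition), compound 3 gives 2.4 nM. Compound 1 `CN(C)CCCNc1ccc(S(=O)(=O)NC(=O)c2ccc(N3CCN(CC4=C(c5ccc(C(F)(F)F)cc5)CC(C)(C)CC4)CC3)cc2Oc2cnc3[nH]ccc3c2)cc1[N+](=O)[O-]` gives 0.89 nM in this assay, and compound 2 `CCN(CC)CCCNc1ccc(S(=O)(=O)NC(=O)c2ccc(N3CCN(CC4=C(c5ccc(C(F)(F)F)cc5)CC(C)(C)CC4)CC3)cc2Oc2cnc3[nH]ccc3c2)cc1[N+](=O)[O-]` gives 0.3 nM. The step of a 2.7-fold higher number from compound 1 to compound 3 (0.43 log units; beyond the scatter) and the step of an 8.0-fold higher number from compound 2 to compound 3 (0.90 log units; beyond the scatter) both place compound 3 behind the two open-chain tails, while a 3.0-fold lower number from compound 1 to compound 2 (0.47 log units; beyond the scatter) shows a modest gain between the two open chains.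

Compound 4 `CC(C)C(=O)N1CCC(CNc2ccc(S(=O)(=O)NC(=O)c3ccc(N4CCN(CC5=C(c6ccc(C(F)(F)F)cc6)CC(C)(C)CC5)CC4)cc3Oc3cnc4[nH]ccc4c3)cc2[N+](=O)[O-])CC1` differs from compound 3 in one place: 1-(isopropylcarbonyl)piperidin-4-yl in place of 1-methylpyrrolidin-3-yl on a saturated chain carbon bound to a nitrogen on an aromatic ring. For the measured compounds named here, none of the measured steps brings a carbonyl group into this end of the chain, so the three steps bear on the change only loosely: they show that exchanges at this chain end move this assay by modest amounts, in either direction, and that the larger rearrangements have so far gone toward higher numbers. A modest shift toward a higher number is therefore expected, roughly a 1.5-fold higher number from compound 3 to compound 4 (0.16 log units; within the scatter), with a wide range around it. Compound 4 is expected to give about 3.5 nM in this assay, between 0.9 nM and 14 nM.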

Compound 4, half-maximal inhibitory concentration: 2.4 nM
The estimate for compound 4 lay 1.5-fold (0.16 log units) above the measured number; the measured number falls inside the stated range.
By their numbers in this assay, from the lowest: compound 2; then compound 1; then compounds 3 and 4 (each within the scatter of the next).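

In this assay the step shows no change at the digits printed from compound 3 to compound 4 (within the scatter): replacing 1-methylpyrrolidin-3-yl with 1-(isopropylcarbonyl)piperidin-4-yl, a larger group with a carbonyl, leaves the read-out in place at this chain end. The two open-chain tails remain ahead of this new group, with an 8.0-fold higher number from compound 2 to compound 4 (0.90 log units; beyond the scatter) and a 2.7-fold higher number from compound 1 to compound 4 (0.43 log units; beyond the scatter) matching the gaps seen for compound 3, so in these four compounds both ring-bearing tails give higher numbers than both open-chain tails. No supporting evidence is available to explain this result.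

Ring size and the group on the ring nitrogen change together in this step, leaving their separate contributions unresolved. A 1-methylpiperidin-4-yl group would separate the two, and a 3-(diethylamino)propyl chain would test whether the diethylamino gain extends to a longer chain.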